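Working notes: bromo on the phenyl of compound 1

This account rests on a few compounds, and the source may have more. Where it says the series, first, only, none or still open, it means among the compounds named here.

Measured in a functional assay on MCF7 cells (Homo sapiens) for cytotoxicity, read by MTT assay and propidium iodide staining, with a stated time of 24 h; a lower number here means a stronger inhibitor, a higher number a weaker inhibitor:
- compound 1 `CN(C)c1ccc(-c2nnc(SCC(=O)c3ccccc3)o2)cc1`: 210 nM
- compound 2 `O=C(CSc1nnc(-c2cccc3ccccc23)o1)c1ccccc1`: 230 nM

Compound 1 and compound 2 stand level, their two values lying within the scatter of each other. Compound 3 `CN(C)c1ccc(-c2nnc(SCC(=O)c3ccc(Br)cc3)o2)cc1` has not yet been measured. It comes from compound 1 by one change, phenyl to 4-bromophenyl: bromo in place of hydrogen on an aromatic carbon. The bromo takes the place of a hydrogen on an aromatic carbon, para to a large group. Going by the values given here, no two measured compounds differ in one place only, so the series offers no measured step as a guide to this change. In this assay, no step beyond the scatter and no firm direction are expected, and the estimated change is a 1.1-fold lower number from compound 1 to compound 3 (0.02 log units; within the scatter). For compound 3 the expected value is 200 nM, with an estimated range of 80 nM to 500 nM.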

Compound 3, half-maximal inhibitory concentration: 550 nM
The estimate for compound 3 lay 2.8-fold (0.44 log units) below the measured number; the measured number lies above the stated range.
By their numbers in this assay, from the lowest: compounds 1 and 2 (each within the scatter of the next); then compound 3.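

In this assay, going by these compounds alone, the only single-place comparison reads a 2.6-fold higher number from compound 1 to compound 3 (0.42 log units; beyond the scatter) and is modest, but it lies beyond the scatter. This phenyl is therefore not indifferent to substitution: one bromo, para to a large group, is enough to shift the number towards weaker inhibition, although this rests on a single pair. Nothing available on these compounds accounts for the shift.

The compounds shown leave open whether fluoro, chloro or methoxy in the same place would move the number as bromo does, and whether an amine or a carboxylic acid there would move it the other way. Also open, on these data alone, is whether 4-bromophenyl in place of phenyl gives a similar step on compound 2, which carries a different group on the other side of the shared core.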